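The source may hold more compounds than are shown below. What is called first, only, known or untested is meant among the compounds shown, and "the series" means these compounds.

Compound 1 `CC(C)(CO)CNC(=O)c1cc2cc(C#N)ccc2n1Cc1cccc(OC(F)(F)F)c1`: in an in vitro ADME assay on microsomes from Gut (Homo sapiens) for metabolic stability, using NADPH (a higher number here means faster removal of the compound, a lower number slower removal), compound 1 gives < 6 mL.min-1.g-1, a limit of the assay.
Compound 2 `N#Cc1ccc2c(c1)cc(C(=O)NCCC(O)C(F)(F)F)n2Cc1cccc(OC(F)(F)F)c1`: in this assay compound 2 gives 26 mL.min-1.g-1.
Compound 3 `N#Cc1ccc2c(c1)cc(C(=O)NCCC(O)(C(F)(F)F)C(F)(F)F)n2Cc1cccc(OC(F)(F)F)c1`: in this assay compound 3 gives < 6 mL.min-1.g-1, again a limit of the assay.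

Compound 3 therefore stands at the floor of the numbers shown, as noted by the limit of < 6 mL.min-1.g-1 in this assay, at which 2 of the 3 values shown sit. Compound 4 `N#Cc1ccc2c(c1)cc(C(=O)NCCC1(O)CCC1)n2Cc1cccc(OC(F)(F)F)c1` differs from it by 1-hydroxycyclobutyl in place of 2,2,2-trifluoro-1-hydroxy-1-(trifluoromethyl)ethyl on a saturated chain carbon, two bonds along the chain from an amide-type nitrogen. Among the measured compounds shown here, two measured steps bear on this change: an at least 4.3-fold lower number from compound 2 to compound 3 (0.63 log units; beyond the scatter) and an at least 4.3-fold higher number from compound 1 to compound 2 (0.63 log units; beyond the scatter). Compound 4 keeps a hydroxyl on the chain but carries no trifluoromethyl, so a rise from the limit is expected in this assay, an at least 2.5-fold higher number from compound 3 to compound 4 (0.39 log units; beyond the scatter), with its size uncertain given that the starting value is only a limit. Compound 4 is estimated at 15 mL.min-1.g-1, in a range from 6 mL.min-1.g-1 to 40 mL.min-1.g-1.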

Compound 4, intrinsic clearance in microsomes: < 6 mL.min-1.g-1
Compound 4 ended at the assay's limit (the forecaster's own chance of this, stated with the estimate: 30%); at least 2.5-fold (0.39 log units) between middle value and limit.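

With 1-hydroxycyclobutyl on the saturated chain carbon, two bonds along the chain from an amide-type nitrogen, this assay shows an at least 4.3-fold lower number from compound 2 to compound 4 (0.63 log units; beyond the scatter), so a low number here does not depend on fluorine in the group. The steps from compound 1 and from compound 3 to compound 4 cannot be read, as both ends of each are limits. Compound 2 now stands alone with a readable value: the limit of < 6 mL.min-1.g-1 in this assay, at which 3 of the 4 values shown sit.

As far as these compounds go, the order of compound 1, compound 3 and compound 4 remains unknown. Whether an amine or a carboxylic acid in place of the hydroxyl stays at that limit is open.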